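Changing the pyridine group of compound 2

The source may report more compounds than this note shows. Statements on the series, on what has been measured and on what is new or still open speak of the compounds shown alone.

Compound 2 `Cc1cccc(-c2noc([C@H](C)NC(=O)c3cc(C(F)(F)F)nn3C)n2)n1` is tested in an assay on T-REx-293 cells for inhibition of potassium channel subfamily T member 1 (Homo sapiens), read by patch clamp (a higher number here means a weaker inhibitor, a lower number a stronger inhibitor), and reaches only > 30000 nM, which is a limit of the measurement rather than a number. Compound 1 `Cc1cccc(-c2nnc([C@H](C)NC(=O)c3cc(C4CC4)nn3C)o2)c1` likewise stops at the limit > 30000 nM. Compound 3 `C[C@H](NC(=O)c1cc(C(F)(F)F)nn1C)c1nc(-c2cnn(C)c2)no1` gives a number, 2640 nM, and the step of an at least 11-fold lower number from compound 2 to compound 3 (1.05 log units; beyond the scatter) shows that the group on that aromatic carbon matters. Compounds 1 and 2 both stop at the same boundary (the limit of > 30000 nM in this assay, at which 2 of the 3 values shown sit). Compound 4 `C[C@H](NC(=O)c1cc(C(F)(F)F)nn1C)c1nc(-c2ccnc(C(F)(F)F)c2)no1` alters the same position of compound 2 in another way: 2-(trifluoromethyl)pyridin-4-yl in place of 6-methylpyridin-2-yl on an aromatic carbon. Going by the values given here, only the step to compound 3 bears on this, and it was large, but the entering group here differs from that one, so a smaller gain is expected. Compound 4 is estimated at 9000 nM, within 2500 nM to 30000 nM, an expected step of an at least 3.3-fold lower number from compound 2 to compound 4 (0.52 log units; beyond the scatter).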

Compound 4, half-maximal inhibitory concentration: 40 nM
Compound 4: the middle estimate sits 230-fold (2.35 log units) above what was measured; measured number outside the range, below it.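

In this assay, a pyridine on this aromatic carbon does not by itself mean a weak inhibitor: exchanging one substituted pyridine for another gives an at least 750-fold lower number from compound 2 to compound 4 (2.87 log units; beyond the scatter). The new group also goes well past the earlier gain from the pyrazole, with a 66-fold lower number from compound 3 to compound 4 (1.82 log units; beyond the scatter). The first of these steps has only a lower bound: the limit of > 30000 nM in this assay, at which 2 of the 4 values shown sit.

As far as these compounds go, compound 2 and compound 4 differ in both the pyridine substituent and the ring carbon that carries the shared core, so the source of the gain stays open. A 2-methylpyridin-4-yl group or a 6-(trifluoromethyl)pyridin-2-yl group would help separate the two.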